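The source may hold more compounds than are shown below. What is called first, only, known or untested is meant among the compounds shown, and "the series" means these compounds.

Among the compounds with values here, compound 2 `CCOC(=O)/C=C/c1cc(OC)ccc1OC(=O)c1nc(C)c(C)nc1C` stands at the higher of the two numbers measured so far: in a functional assay on EA.hy 926 cells (Homo sapiens) for cytotoxicity, read by MTT assay, with stated times of 24 h and 12 h, tested at 12.5 uM (on this read-out lower numbers stand for a weaker effect and higher numbers for a stronger effect at the one concentration tested), compound 2 gives 15.9%, whereas compound 1 `CCOC(=O)/C=C/c1ccc(OC)cc1OC(=O)c1nc(C)c(C)nc1C` gives -57.6%, a gap that lies beyond the usual scatter. Compound 3 `CCOC(=O)/C=C/c1ccccc1OC(=O)c1nc(C)c(C)nc1C` differs from compound 2 in one place: hydrogen in place of methoxy on an aromatic carbon. Within the data shown here, no pair of measured compounds differs in exactly one place, so no measured step shows how large such a change tends to be. Compound 3 is therefore expected to give 10% in this assay, with a range from -30% to 40%. The expected step of a number 5.9 percentage points lower from compound 2 to compound 3 (within the scatter) is estimated to stay within the scatter.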

Compound 3, a percentage reported as activity, at one concentration (the size of the read-out at that concentration, not a potency): 9.6%
Estimate against measurement, compound 3: 0.4 percentage points above; measured number inside the range.
By their numbers in this assay, from the lowest: compound 1; then compounds 3 and 2 (each within the scatter of the next).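

In this assay, hydrogen in place of methoxy para to a large group gives a number 6.3 percentage points lower from compound 2 to compound 3 (within the scatter) and so no change that stands out from the scatter. The same swap at the other methoxy place gives a number 67.2 percentage points higher from compound 1 to compound 3 (beyond the scatter) and thus shows that the size of this change depends on where the methoxy sat. Nothing measured here explains that contrast. Still open, on these data alone, is how other groups at these two places, such as an amine, a carboxylic acid or a longer ether chain, would compare.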